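Cytotoxicity notes on the shared-core series

This account rests on a few compounds, and the source may have more. Where it says the series, first, only, none or still open, it means among the compounds named here.

Three analogues have been checked in an ADME assay on HepG2 2.2.15 cells (Homo sapiens) for cytotoxicity; on this read-out higher numbers stand for lower toxicity in this test and lower numbers for higher toxicity in this test. Compound 1 `O=C(Nc1ncc(Cc2ccc(Cl)cc2)s1)c1ccc(F)cc1F` gives "not toxic" (no number reported) in this assay. Compound 2 `CC(C)(C)OC(=O)Nc1ncc(C(Oc2ccc(Cc3ccccc3)cc2)c2ccc(Cl)cc2)s1` reaches only a limit of the measurement, > 50000 nM, in this assay. Compound 3 `COCCCNc1ncc(C(Oc2ccc3cc(Br)ccc3c2)c2ccc(Cl)cc2)s1` gives "not toxic" (no number reported) in this assay. Compound 3 therefore stands without a single number; of the two other entries, one is a limit and one again carries no number, so nothing on this read-out separates the three, and the limit of > 50000 nM in this assay, at which 1 of the 3 values shown sits, is the only quantitative anchor the set has.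

Among the measured compounds shown here, no pair among the measured compounds differs in just one place, so no measured step exists to lean on.

Compound 4 `O=C(Nc1ncc(C(Oc2ccc3cc(Br)ccc3c2)c2ccc(Cl)cc2)s1)c1ccc(Cl)nc1` differs from compound 3 by (6-chloropyridin-3-yl)carbonyl in place of 3-methoxypropyl on a nitrogen on an aromatic ring. For the measured compounds named here, the exchange of a 3-methoxypropyl for a (6-chloropyridin-3-yl)carbonyl on a nitrogen on an aromatic ring has no measured counterpart here. The step from compound 3 to compound 4 in this assay is expected to stay within the scatter, with neither a gain nor a loss in toxicity beyond it, in line with compound 2 at the limit of > 50000 nM in this assay, at which 1 of the 3 values shown sits, and compounds 1 and 3 carrying no number. Compound 4 is accordingly expected at 60000 nM in this assay, with a range from 25000 nM to 200000 nM, and most likely only a limit will be reported again.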

Compound 4, half-maximal cytotoxic concentration: "not toxic" (no number reported)
Compound 4 has no reported number here; no gap can be computed for the estimate.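

In this assay compound 3 gives "not toxic" (no number reported) and compound 4 gives "not toxic" (no number reported), so no step can be read between them. The compounds shown leave open whether any change on the shared core shifts this read-out at all, with a single quantitative anchor for the series: the limit of > 50000 nM in this assay, at which 1 of the 4 values shown sits.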